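From methyl(phenyl)amino to (phenylcarbamoyl)amino on the sulfonyl sulfur

The compounds below may be only part of what the source reports. "The series", "measured", "known", "first", "only" and "open" are said of these compounds alone.

Compound 2 `CN(c1ccccc1)S(=O)(=O)c1ccc2c(c1)C(n1ccccc1=O)=CC(C)(C)O2` and compound 1 `CC1(C)C=C(n2ccccc2=O)c2cc(S(=O)(=O)Nc3ccc(C#N)cc3)ccc2O1` share the same core and differ only in the group on the sulfonyl sulfur. In a functional assay on the whole organism (trachea) with Rattus norvegicus as the target (a lower number here means a smaller maximal response, a higher number a larger maximal response), compound 1 gives 90.8%, and compound 2 gives 86.5%. Within the data shown here, the one measured step, a number 4.3 percentage points lower from compound 1 to compound 2 (within the scatter), lies within the scatter, so the two numbers cannot be told apart; of the two, compound 2 carries the smaller number, but the gap to compound 1 is within the scatter.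

Compound 3 `CC1(C)C=C(n2ccccc2=O)c2cc(S(=O)(=O)NC(=O)Nc3ccccc3)ccc2O1` has not yet been measured. ((phenylcarbamoyl)amino in place of methyl(phenyl)amino on a sulfonyl sulfur). Among the measured compounds shown here, the only step that bears on this change is the earlier exchange at the same sulfonyl sulfur, a number 4.3 percentage points lower from compound 1 to compound 2 (within the scatter), which changed little. The entering (phenylcarbamoyl)amino brings hydrogen-bond donors and an acceptor that neither earlier group had, so the guide is thin, but with a single within-scatter step as precedent I expect no shift beyond the scatter, a number 0.5 percentage points lower from compound 2 to compound 3 (within the scatter). Compound 3 is estimated at 86%, within a range from 70% to 100%.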

Compound 3, largest response reached (Emax), in percent of the reference or control that the assay uses: 99.5%
Beside the measured number, compound 3's estimate is 13.5 percentage points below it; the measured number falls inside the stated range.
By their numbers in this assay, from the lowest: compounds 2, 1 and 3 (each within the scatter of the next, the first and the last beyond it).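

In this assay, the exchange on the sulfonyl sulfur gives a number 13 percentage points higher from compound 2 to compound 3 (beyond the scatter), so this position can move the maximal response past the scatter, although the step is modest and the earlier exchange there did not do so. The change of group on the sulfonamide nitrogen gives a number 8.7 percentage points higher from compound 1 to compound 3 (within the scatter), so phenylcarbamoyl and 4-cyanophenyl cannot be told apart at this position, and the one clear difference among these compounds is that between the two ends of the series, with the value of compound 1 falling within the scatter of both. Nothing measured here accounts for the step, and its origin remains unknown.

On these data alone, it remains open how much of the phenylcarbamoyl group is needed, which a smaller acetyl group on the sulfonamide nitrogen would help to test, as would a plain amino group on the sulfonyl sulfur. As far as these compounds go, it is also open whether the phenyl ring of (phenylcarbamoyl)amino matters, which a methylcarbamoyl group on the same nitrogen could show.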